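The source may report more compounds than this note shows. Statements on the series, on what has been measured and on what is new or still open speak of the compounds shown alone.

Measured in an ADME assay on HEK293 cells (Homo sapiens) for cytotoxicity, read by reporter gene assay and resazurin assay, with a stated time of 48 h; on this read-out lower numbers stand for higher toxicity in this test and higher numbers for lower toxicity in this test:
- compound 1 `O=C(Nc1cccc(Cl)c1)c1ccccc1O`: 37000 nM
- compound 2 `O=C(Nc1ccc(Sc2nc3ccccc3s2)cc1)c1cc(Br)cc(Br)c1`: > 100000 nM (a limit)
- compound 3 `O=C(Nc1ccc(Sc2nc3ccccc3s2)cc1)c1ccccc1`: > 100000 nM (a limit)

Compound 3 is known only as a limit, > 100000 nM. This is the limit of > 100000 nM in this assay, at which 2 of the 3 values shown sit. Compound 4 `O=C(Nc1ccc(Sc2nc3ccccc3s2)cc1)c1cccc(Br)c1O` differs from it by one change: 3-bromo-2-hydroxyphenyl in place of phenyl on a carbonyl carbon. In words, 3-bromo-2-hydroxyphenyl stands in place of phenyl on a carbonyl carbon. For the measured compounds named here, the one measured step at this place is a step that the two limits leave unreadable from compound 2 to compound 3, so it sets no size. Compound 1, which also has a hydroxy group on the aromatic ring at its carbonyl carbon, gives 37000 nM, and this points to a lower number for compound 4 in this assay. The expected step is an at least 2.8-fold lower number from compound 3 to compound 4 (0.45 log units; beyond the scatter). Compound 4 is estimated at 35000 nM, with an expected range from 8000 nM to 100000 nM.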

Compound 4, half-maximal cytotoxic concentration: 71000 nM
Estimate against measurement, compound 4: 2.0-fold (0.31 log units) below; the range from low to high includes it.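

In this assay, 3-bromo-2-hydroxyphenyl on the carbonyl carbon gives compound 4 a measured number on the shared core, where compound 2 and compound 3 are known only as limits. The steps are an at least 1.4-fold lower number from compound 3 to compound 4 (0.14 log units; that floor lies within the scatter) and an at least 1.4-fold lower number from compound 2 to compound 4 (0.14 log units; that floor lies within the scatter), so neither floor alone shows a change beyond the scatter. The step between compound 2 and compound 3 cannot be read, and the full sizes of the other two stay open because compound 2 and compound 3 are limits: the limit of > 100000 nM in this assay, at which 2 of the 4 values shown sit.

The compounds shown leave open whether the hydroxy group or the bromine carries the step, and what an amine or a carboxylic acid on this ring would give.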